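Methyl added to the chloro analogue: expected stability

The compounds below may be only part of what the source reports. "The series", "measured", "known", "first", "only" and "open" are said of these compounds alone.

Compound 1 `C=CC(=O)N1CC(NC(=O)Cn2c(C)c(C(=O)N3CCc4c(cccc4OC)C3)c3cc(Br)cc(C)c32)C1`: in a physicochemical assay for pharmacokinetics, read by LC-MS, in phosphate buffer, at pH 7.4, in the presence of a further agent that is not named here (a higher number here means that the compound lasts longer, a lower number that the compound disappears faster), compound 1 gives 1.67 h.
Compound 2 `C=CC(=O)N1CC(NC(=O)Cn2c(C)c(C(=O)N3CCc4c(cccc4OC)C3)c3cc(Cl)ccc32)C1`: in this assay compound 2 gives 1.67 h.

Compound 2 stands level with compound 1 at the digits shown; the two half-lives read the same, within the scatter, and no ordering between them can be drawn.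

Compound 3 `C=CC(=O)N1CC(NC(=O)Cn2c(C)c(C(=O)N3CCc4c(cccc4OC)C3)c3cc(Cl)cc(C)c32)C1` has not yet been run. It differs from compound 2 in one place: methyl in place of hydrogen on an aromatic carbon. Within the data shown here, no step between two measured compounds isolates this change, so the size of the step is not known from a direct pair. What the data do show is that compound 1, which also carries a methyl on its core, reads in this assay at 1.67 h, the same number as compound 2 at the digits shown.

On that basis no step beyond the scatter is expected. Compound 3 is estimated at 1.67 h, with a range from 0.9 h to 3.2 h. The expected step of no change at the digits printed from compound 2 to compound 3 (within the scatter) is accordingly none beyond the scatter, in either direction.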

Compound 3, half-life: 1.67 h
Estimate against measurement, compound 3: no gap at the digits printed; the measured number falls inside the stated range.
By their numbers in this assay, from the lowest: compounds 1, 2 and 3 (each within the scatter of the next).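

In this assay, methyl in place of hydrogen on this aromatic carbon, ortho to a fused ring and meta to a chloro group, now has a direct pair, and the step reads no change at the digits printed from compound 2 to compound 3 (within the scatter). With that methyl present in both compounds, chloro in place of bromo on an aromatic carbon can also be read on its own, as no change at the digits printed from compound 1 to compound 3 (within the scatter). No supporting evidence bears on the reason for these readings.

Going by these compounds, what an amine or a carboxylic acid on this same aromatic carbon would do to the half-life remains open, as does the effect of a longer chain such as ethyl. Also open, on these data alone, is whether the same reading would hold with fluoro or a nitrile in place of the chloro group.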